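The source may hold more compounds than are shown below. What is called first, only, known or untested is meant among the compounds shown, and "the series" means these compounds.

Among the measured compounds shown here, compound 1 `O=C(NCCCCc1cccnc1)c1ccc(-c2cccc(O)c2)cc1` gives 300 nM in an assay (Canis lupus familiaris) for binding affinity to platelet-activating factor receptor (Homo sapiens), read by radioligand binding (on this read-out lower numbers stand for stronger inhibition and higher numbers for weaker inhibition), the higher of the two numbers measured so far. Compound 2 `CCCCc1cc(C(=O)N[C@H](C)CCCc2cccnc2)ccc1-c1ccc(OC)c(OC)c1` gives 4 nM in this assay, yet it differs from compound 1 in several places at once, so those two values are all that pair shows. Compound 3 `Cc1cccc(-c2ccc(C(=O)NCCCCc3cccnc3)cc2)c1` differs from compound 1 in a single place: methyl in place of hydroxy on an aromatic carbon. For the measured compounds named here, no measured pair carries this exact change, so only a small step is expected, a 1.2-fold lower number from compound 1 to compound 3 (0.08 log units; within the scatter), lying within the usual scatter in either direction. Compound 3 is therefore expected to give about 250 nM, somewhere between 70 nM and 900 nM.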

Compound 3, half-maximal inhibitory concentration: 500 nM
Compound 3: the middle estimate sits 2.0-fold (0.30 log units) below what was measured, within the range that was stated.
By their numbers in this assay, from the lowest: compound 2; then compounds 1 and 3 (each within the scatter of the next).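

Putting methyl in place of hydroxy on this aromatic carbon gives a 1.7-fold higher number from compound 1 to compound 3 (0.22 log units; within the scatter) in this assay. At this place, then, a hydroxy group with its hydrogen-bond donor and acceptor can give way to a methyl group with neither, and the number stays within the scatter. Nothing measured here offers a reason for this result. The compounds shown leave open whether an amine, a carboxylic acid or a longer chain at this place would also stay within the scatter of compound 1.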